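Anilide variation on a furyl-triazole thioacetamide series

A few compounds are considered here, and "the series" means these few. Any claim that something is new, unique, unknown or untested is made for them only; others in the source may bear on it.

compound 1 `Cc1ccc(C)c(NC(=O)CSc2nnc(-c3ccoc3C)n2Cc2ccco2)c1`: > 15800 nM
compound 2 `Cc1cccc(C)c1NC(=O)CSc1nnc(-c2ccoc2C)n1Cc1ccco1`: > 15800 nM

In a functional assay on CHO cells for antagonist activity at Orexin/Hypocretin receptor type 1 (Homo sapiens), read by FLIPR and calcium flux (on this read-out higher numbers stand for weaker inhibition and lower numbers for stronger inhibition), compound 1 reaches only the limit > 15800 nM. Compound 2 stands at that same limit, > 15800 nM, so nothing more than a bound is known for it. The step that the two limits leave unreadable from compound 1 to compound 2 is accordingly unreadable, as the limit of > 15800 nM in this assay, at which 2 of the 2 values shown sit, records. Compound 3 `Cc1cccc(NC(=O)CSc2nnc(-c3ccoc3C)n2Cc2ccco2)c1` carries 3-methylphenyl in place of 2,6-dimethylphenyl on an amide-type nitrogen. No readable step bears on this change; the only measured one stops at the limit. Compound 3 is therefore expected to remain weak, at an estimated 20000 nM (range 4000 nM to 100000 nM), most probably reported again as a limit. The expected step that the limit leaves unreadable from compound 2 to compound 3 is thus itself unlikely to be readable.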

Compound 3, inhibition constant: 2510 nM
Estimate against measurement, compound 3: 8.0-fold (0.90 log units) above; measured number below the stated range.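

In this assay, the group on the amide-type nitrogen can move the read-out off the limit, so this position is not silent. 3-Methylphenyl in place of 2,6-dimethylphenyl gives an at least 6.2-fold lower number from compound 2 to compound 3 (0.79 log units; beyond the scatter), and hydrogen in place of methyl on an aromatic carbon gives an at least 6.2-fold lower number from compound 1 to compound 3 (0.79 log units; beyond the scatter). Both sizes are only lower bounds, since each step starts from a limit: the limit of > 15800 nM in this assay, at which 2 of the 3 values shown sit.

From the compounds shown here alone, what an unsubstituted phenyl, or a chlorine or methoxy group in place of the methyl of 3-methylphenyl, would give remains open. Also open, going by these compounds, is whether a single methyl elsewhere on the ring would serve equally well.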